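Methoxy Added to an Indolyl Acrylonitrile Cytotoxic Agent

The compounds below may be only part of what the source reports. "The series", "measured", "known", "first", "only" and "open" are said of these compounds alone.

Measured compounds:
Compound 1, `COc1ccc(Cn2cc(/C=C(\C#N)C(=O)c3c[nH]c4cc(OC)ccc34)c3ccccc32)cc1`: > 50000 nM (a limit)
Compound 2, `N#C/C(=C\c1c[nH]c2ccccc12)C(=O)c1c[nH]c2ccccc12`: 36800 nM

Of the compounds shown here, two have been tested in a functional assay on MIA PaCa-2 cells (Homo sapiens) for cytotoxicity, read by WST assay, with a stated time of 48 h; on this read-out higher numbers stand for weaker inhibition and lower numbers for stronger inhibition. Compound 1 reaches only (the limit of > 50000 nM in this assay, at which 1 of the 2 values shown sits), so no number is known for it. For the measured compounds named here, compound 2 is the sole compound with a measured number, giving 36800 nM in this assay; it therefore stands as the one fixed point of the set. Compound 3, `COc1ccc2c(C(=O)/C(C#N)=C/c3c[nH]c4ccccc34)c[nH]c2c1`, has not yet been measured. It differs from compound 2 by methoxy in place of hydrogen on an aromatic carbon. Going by the values given here, no step between two measured compounds is available to guide the size of this change, and compound 1, which carries a methoxy group on the same part of the core together with other changes, offers only a limit. Compound 3 is therefore expected to sit close to compound 2, with a step of a 1.1-fold higher number from compound 2 to compound 3 (0.04 log units; within the scatter) that is not expected to exceed the scatter in either direction. Compound 3 is estimated at 40000 nM, between 15000 nM and 120000 nM.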

Compound 3, half-maximal inhibitory concentration: > 50000 nM
Compound 3: no number, only a limit; the forecaster's own chance of this, stated with the estimate: 35%; middle value at least 1.2-fold (0.09 log units) away from the limit.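

In this assay compound 3 gives > 50000 nM, which is a limit of the assay and not a number. Methoxy in place of hydrogen on an aromatic carbon thus yields the first single change in this series, an at least 1.3-fold higher number from compound 2 to compound 3 (0.13 log units; that floor lies within the scatter), so only a floor is known and the methoxy compound shows no gain over its parent at this position. The step that separates compound 1 from compound 3 cannot be read, and the series now gathers at one ceiling: the limit of > 50000 nM in this assay, at which 2 of the 3 values shown sit.

Going by these compounds, the true size of the methoxy step remains open, since compound 3 has no number. Also open, on these data alone, is whether a hydroxy group or an amine on this same aromatic carbon would give a value that can be read in this assay.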